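A few compounds are considered here, and "the series" means these few. Any claim that something is new, unique, unknown or untested is made for them only; others in the source may bear on it.

Working notes on the series. Compound 1 `N/C(=N\O)c1ccc(S(=O)(=O)C2=C(c3ccccc3)OC(c3ccccc3)(c3ccccc3)C2)cc1` gives in an ADME assay on THP-1 cells (Homo sapiens) for cytotoxicity, read by flow cytometry, with a stated time of 72 h (on this read-out lower numbers stand for stronger inhibition and higher numbers for weaker inhibition), 37900 nM; compound 2 `CC1(c2ccccc2)CC(S(=O)(=O)c2ccc(/C(N)=N/O)cc2)=C(c2ccccc2)O1` gives in this assay 54700 nM, and the two numbers stand within the scatter of each other. Among the measured compounds shown here, the only measured step, a 1.4-fold higher number from compound 1 to compound 2 (0.16 log units; within the scatter), exchanges phenyl for methyl on a saturated ring carbon and stays within the scatter.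

Compound 3 `N/C(=N\O)c1ccc(S(=O)(=O)C2=C(c3ccc(Nc4cccc(/C(N)=N/O)c4)cc3)OC(c3ccccc3)(c3ccccc3)C2)cc1` is not yet measured. It differs from compound 1 by a group of 11 heavy atoms (7 carbon, 3 nitrogen, 1 oxygen; one six-membered aromatic ring of carbon only) in place of a hydrogen atom, on an aromatic carbon. For the measured compounds named here, no measured step touches this position or this kind of group; the single step on record, a 1.4-fold higher number from compound 1 to compound 2 (0.16 log units; within the scatter), concerns another part of the shared core and was itself within the scatter, so it points in no direction for the new change. With only that to go on, no step beyond the scatter is expected in this assay, and the estimated step of a 1.3-fold lower number from compound 1 to compound 3 (0.10 log units; within the scatter) carries a wide range. Compound 3 is therefore expected at 30000 nM in this assay, with a range of 8000 nM to 120000 nM.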

Compound 3, half-maximal inhibitory concentration: 48100 nM
Estimate against measurement, compound 3: 1.6-fold (0.21 log units) below, and the stated range covers the measured number.
By their numbers in this assay, from the lowest: compounds 1, 3 and 2 (each within the scatter of the next).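

In this assay the aromatic carbon para to a large group accepts a group of 11 heavy atoms, with one six-membered aromatic ring of carbon only, in place of a hydrogen atom, and the result is a 1.3-fold higher number from compound 1 to compound 3 (0.10 log units; within the scatter). Among the compounds shown here, the earlier step concerned a saturated ring carbon, so this is the first sign that a change at this aromatic carbon, even one this large, need not move the number beyond the scatter. No measurement at hand bears on what lies behind this result.

Still open, from the compounds shown here alone, is whether a small group on the same carbon, such as an amine, a methoxy group or a carboxylic acid, would stay within the scatter as well. Also open, going by these compounds, is whether the group of 11 heavy atoms behaves alike with methyl in place of phenyl on the saturated ring carbon.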